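The source may hold more compounds than are shown below. What is called first, only, known or untested is meant among the compounds shown, and "the series" means these compounds.

Compound 1 `CCN(CC)S(=O)(=O)c1ccc(S(=O)(=O)N2CCC[C@@H](C(=O)N3CCC(F)(F)CC3)C2)cc1`: in a functional assay on MIA PaCa-2 cells (Homo sapiens) for inhibition, read by MTT assay, with a stated time of 3 days (on this read-out lower numbers stand for stronger inhibition and higher numbers for weaker inhibition), compound 1 gives > 10000 nM, a limit of the assay rather than a number.
Compound 2 `CCN(CC)S(=O)(=O)c1ccc(S(=O)(=O)N2CCC[C@@H](C(=O)N3CCC(C(F)(F)F)CC3)C2)cc1`: in this assay compound 2 gives > 10000 nM, likewise a limit.
Compound 3 `CCN(CC)S(=O)(=O)c1ccc(S(=O)(=O)N2CCC[C@@H](C(=O)N3CCOCC3)C2)cc1`: in this assay compound 3 gives > 10000 nM, again a limit.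

Compound 3 therefore stands where every compound shown stands, at the limit of > 10000 nM in this assay, at which 3 of the 3 values shown sit. The next compound, compound 4 `CCN(CC)S(=O)(=O)c1ccc(S(=O)(=O)N2CCC[C@@H](C(=O)N[C@H]3CC[C@@H](OC)CC3)C2)cc1`, differs from compound 3 by (4-methoxycyclohexyl)amino in place of morpholin-4-yl on a carbonyl carbon. Among the measured compounds shown here, the steps that bear on this change, a step that the two limits leave unreadable from compound 1 to compound 3 and a step that the two limits leave unreadable from compound 2 to compound 3, are both unreadable because both ends sit at a limit, as is a step that the two limits leave unreadable from compound 1 to compound 2. No measured step among these compounds gives a readable size, so nothing here supports expecting a change beyond the scatter in this assay. Compound 4 is expected at 15000 nM, between 3000 nM and 60000 nM, an expected step that the limit leaves unreadable from compound 3 to compound 4.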

Compound 4, half-maximal inhibitory concentration: > 10000 nM
Compound 4: only a limit was reported; the forecaster's own chance of this, stated with the estimate: 75%; the middle value does not contradict the limit.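

In this assay compound 4 gives > 10000 nM as a limit of the assay. Among the compounds shown here, no step to compound 4 from compound 1, compound 2 or compound 3 can be read. Going by these compounds, whether these groups on the carbonyl carbon differ at all in this assay stays open.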